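Fluoro for Methoxy: What Compound 3 May Show

The source may hold more compounds than are shown below. What is called first, only, known or untested is meant among the compounds shown, and "the series" means these compounds.

Of the compounds shown here, two have been measured so far in a functional assay on A-375 cells (Homo sapiens) for inhibition, read by CCK-8 assay, with a stated time of 72 h, tested at 8 uM; a lower number here means less inhibition of growth, a higher number more inhibition of growth at the concentration tested. Compound 1 `COc1ccc(SCc2ccc(/C=C/C(=O)Nc3ccccc3N)cc2)cc1OC` is one of them, and in this assay compound 1 gives 46.4%. Compound 2 `COc1ccc(SCc2ccc(C(=O)Nc3ccccc3N)cc2)cc1` is the other, and in this assay compound 2 gives 81.8%. Compound 2 thus stands at the highest of the two numbers shown, and its gap to compound 1 lies beyond the usual scatter of this kind of measurement. No single-point step between measured compounds is shown, so the two values say only where each compound stands.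

Compound 3 `Nc1ccccc1NC(=O)c1ccc(CSc2ccc(F)cc2)cc1` has not yet been measured. It differs from compound 2 by fluoro in place of methoxy on an aromatic carbon. For the measured compounds named here, nothing among the measured compounds shows how a change at this place moves the read-out. With that in mind, the step from compound 2 to compound 3 is expected to be small, a number 7.8 percentage points lower from compound 2 to compound 3 (within the scatter), and not clearly beyond the scatter in either direction. Compound 3 is therefore estimated to give 74%, with a plausible range from 52% to 92%.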

Compound 3, percent growth inhibition at one concentration: 54.3%
The estimate for compound 3 lay 19.7 percentage points above the measured number; the range from low to high includes it.
By their numbers in this assay, from the lowest: compounds 1 and 3 (each within the scatter of the next); then compound 2.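

The step from 4-methoxyphenyl to 4-fluorophenyl in this assay is a number 27.5 percentage points lower from compound 2 to compound 3 (beyond the scatter) and gives the first reading of a change in one place among these compounds. It shows that this aromatic carbon, para to a large group, is not indifferent to what it carries: with the rest of compound 2 unchanged, replacing methoxy with fluoro moves growth inhibition at the tested concentration by more than the usual scatter. No measurement at hand bears on why the number moves at this position.

The compounds shown leave open whether the step follows from the loss of methoxy or from the arrival of fluoro, and a hydrogen atom, chloro, hydroxy, or an amine on the same carbon would help to separate the two. Also open, from the compounds shown here alone, is whether the same exchange would move the number in the same direction on another core, such as that of compound 1, or only on the core shared by compound 2 and compound 3.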